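The source may hold more compounds than are shown below. What is called first, only, known or untested is meant among the compounds shown, and "the series" means these compounds.

Working notes, sulfonamide series. Among the compounds with values here, compound 2 `COc1ccc(NS(=O)(=O)c2ccc3c(c2)C(n2ccccc2=O)=CC(C)(C)O3)cc1` gives 84.2% in a functional assay on the whole organism (trachea) with Rattus norvegicus as the target; on this read-out lower numbers stand for smaller maximal responses and higher numbers for larger maximal responses; of the two numbers so far it stands together with compound 1 `CC1(C)C=C(n2ccccc2=O)c2cc(S(=O)(=O)NCc3ccccc3)ccc2O1`, which gives 77.5%, the gap being a number 6.7 percentage points higher from compound 1 to compound 2 (within the scatter). Compound 3 `CN(c1ccccc1)S(=O)(=O)c1ccc2c(c1)C(n1ccccc1=O)=CC(C)(C)O2` is not yet measured; it differs from compound 2 by methyl(phenyl)amino in place of (4-methoxyphenyl)amino on a sulfonyl sulfur. Within the data shown here, the only measured step that bears on this, the change on the sulfonamide nitrogen from compound 1 to compound 2, stayed within the scatter, so no step beyond the scatter is expected in this assay. For compound 3 the estimate is 82%, in the range 70% to 92%, an expected step of a number 2.2 percentage points lower from compound 2 to compound 3 (within the scatter).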

Compound 3, largest response reached (Emax), in percent of the reference or control that the assay uses: 86.5%
Compound 3: middle estimate off by 4.5 percentage points, on the low side; the range from low to high includes it.
By their numbers in this assay, from the lowest: compounds 1, 2 and 3 (each within the scatter of the next).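

In this assay the sulfonyl sulfur takes methyl(phenyl)amino, which has no hydrogen-bond donor, in place of (4-methoxyphenyl)amino (a number 2.3 percentage points higher from compound 2 to compound 3 (within the scatter)) and in place of benzylamino (a number 9 percentage points higher from compound 1 to compound 3 (within the scatter)). Neither step leaves the scatter, so across compounds 1, 2 and 3, the donor on this nitrogen is not needed to hold the maximal response. No evidence to hand accounts for this flat result.

Each of the three groups carries a phenyl ring. On these data alone, whether dimethylamino, or a phenyl ring bearing a carboxylic acid, would give a step beyond the scatter remains open.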